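The source may hold more compounds than are shown below. What is called first, only, known or untested is meant among the compounds shown, and "the series" means these compounds.

Working notes on the series. Compound 1 `COc1cccc(OC)c1OCCNCCOc1ccccc1OCc1ccc(Cl)cc1` gives 0.0316 nM in an assay on CHO cells for displacement of a labelled ligand from Alpha-1D adrenergic receptor (Homo sapiens); on this read-out higher numbers stand for weaker inhibition and lower numbers for stronger inhibition. Going by the values given here, compound 2 `COc1cccc(OC)c1OCCNCCOc1ccccc1OCc1ccccc1[N+](=O)[O-]` gives 0.912 nM in this assay, the highest of the two numbers measured so far; the one step measured, a 29-fold higher number from compound 1 to compound 2 (1.46 log units; beyond the scatter), is large and beyond the scatter.

The next member, compound 3 `COc1ccccc1COc1ccccc1OCCNCCOc1c(OC)cccc1OC`, differs from compound 2 by methoxy in place of nitro on an aromatic carbon. Among the compounds with values here, the only measured step concerns a different exchange on the same aromatic ring, and it gives no direct guide to this change; nothing measured yet tells how the replacement of nitro by methoxy at this position moves the number. Within the data shown here, the expectation is therefore a step of a 1.8-fold lower number from compound 2 to compound 3 (0.26 log units; within the scatter), not clearly beyond the scatter in either direction, with wide uncertainty given the size of the single known step. Compound 3 is estimated to give 0.5 nM in this assay, within a range of 0.08 nM to 3 nM.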

Compound 3, inhibition constant: 2 nM
The estimate for compound 3 lay 4.0-fold (0.60 log units) below the measured number; the measured number falls inside the stated range.
By their numbers in this assay, from the lowest: compound 1; then compound 2; then compound 3.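

In this assay, the exchange of nitro for methoxy on this aromatic carbon now has a direct measure: a 2.2-fold higher number from compound 2 to compound 3 (0.34 log units; beyond the scatter) is a modest step, but it shows that the position is not indifferent to this change. Against 4-chlorophenyl, the 2-methoxyphenyl group gives a 63-fold higher number from compound 1 to compound 3 (1.80 log units; beyond the scatter) and so stays on the same high side as 2-nitrophenyl, with a 29-fold higher number from compound 1 to compound 2 (1.46 log units; beyond the scatter) as the smaller of the two large steps. No measurement at hand bears on the cause of either step.

The compounds shown leave open whether the gap to compound 1 follows the identity of the group or its place on the ring, a question that 2-chlorophenyl and 4-methoxyphenyl would separate. Also open, going by these compounds, is how an amine or a carboxylic acid on this aromatic carbon would compare with nitro and methoxy.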